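Swapping the thiophene arm for a dichlorophenyl on a shared core

The compounds below may be only part of what the source reports. "The series", "measured", "known", "first", "only" and "open" are said of these compounds alone.

Measured compounds:
compound 1 `Cc1ccc(CNc2nc(-c3ccccc3C(F)(F)F)nc3ccccc23)s1` — 5100 nM
compound 2 `FC(F)(F)c1ccccc1-c1nc(NCc2ccccc2)c2ccccc2n1` — 3100 nM
compound 3 `Fc1ccc(CNc2nc(-c3ccccc3C(F)(F)F)nc3ccccc23)cc1` — 3400 nM

All three were measured in an assay on a protein complex for inhibition of ubiquitin carboxyl-terminal hydrolase 1/WD repeat-containing protein 48 (Homo sapiens), read by fluorescence; on this read-out lower numbers stand for stronger inhibition and higher numbers for weaker inhibition. Compound 1 is set apart from the other two only by a 1.6-fold lower number from compound 1 to compound 2 (0.22 log units; within the scatter) and by a 1.5-fold lower number from compound 1 to compound 3 (0.18 log units; within the scatter), so the three numbers sit together and no ordering among them can be claimed. Between the other two, a 1.1-fold higher number from compound 2 to compound 3 (0.04 log units; within the scatter) shows that a fluoro on the aromatic ring left the number essentially unchanged.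

Compound 4 `FC(F)(F)c1ccccc1-c1nc(NCc2ccc(Cl)c(Cl)c2)c2ccccc2n1` has not been measured. Relative to compound 1 it carries the change (3,4-dichlorophenyl in place of 5-methylthiophen-2-yl on a saturated chain carbon bound to a nitrogen on an aromatic ring). Going by the values given here, the steps that bear on this are the two exchanges of the same 5-methylthiophen-2-yl for a phenyl or a 4-fluorophenyl, each of which lowered the number only slightly and within the scatter. Among the compounds with values here, a 3,4-dichlorophenyl is a further variation on that aromatic ring, and no step here tells how two chloro groups behave. Compound 4 is therefore expected to give a number modestly lower than compound 1, roughly a 2.0-fold lower number from compound 1 to compound 4 (0.31 log units; beyond the scatter), with the shift possibly staying within the scatter. The estimate for compound 4 in this assay is 2500 nM, with a range from 900 nM to 7000 nM.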

Compound 4, half-maximal inhibitory concentration: 10400 nM
Estimate against measurement, compound 4: 4.2-fold (0.62 log units) below; measured number outside the range, above it.
By their numbers in this assay, from the lowest: compounds 2, 3 and 1 (each within the scatter of the next); then compound 4.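

In this assay, the position on a saturated chain carbon bound to a nitrogen on an aromatic ring turned out not to be indifferent to what it carries: the 3,4-dichlorophenyl gave a 2.0-fold higher number from compound 1 to compound 4 (0.31 log units; beyond the scatter) and a 3.1-fold higher number from compound 3 to compound 4 (0.49 log units; beyond the scatter) and a 3.4-fold higher number from compound 2 to compound 4 (0.53 log units; beyond the scatter). Going by these compounds alone, the exchanges among 5-methylthiophen-2-yl, phenyl and 4-fluorophenyl had all stayed within the scatter, so this is the first change here to pass beyond it, and it moves towards weaker inhibition, leaving compound 4 the weakest of the four. No measurement shown accounts for this shift.

Going by these compounds, whether a single chloro on the phenyl would already raise the number, or only the two together do so, stays open. So does how a carboxylic acid or an amine on that ring, or a longer chain to it, would read in this assay.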